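Trypsin selectivity across a heteroaryl swap

The source may report more compounds than this note shows. Statements on the series, on what has been measured and on what is new or still open speak of the compounds shown alone.

Compound 1 `NC(=O)c1nn(-c2ccc3onc(N)c3c2)c2c(F)c(-c3ccc(N4CCCCC4=O)cc3F)ccc12`: > 10000 nM
Compound 2 `CN(C)Cc1[nH]ncc1-c1ccc(-c2ccc3c(C(N)=O)nn(-c4ccc5onc(N)c5c4)c3c2F)c(F)c1`: > 10000 nM

In an assay on isolated protein for inhibition of Trypsin (Homo sapiens) (a higher number here means a weaker inhibitor, a lower number a stronger inhibitor), compound 1 gives > 10000 nM, which is a limit of the assay rather than a number. In this assay compound 2 gives > 10000 nM, again a limit. The step that the two limits leave unreadable from compound 1 to compound 2 therefore cannot be read, as the limit of > 10000 nM in this assay, at which 2 of the 2 values shown sit, shows. Compound 2 thus stands at the limit, and nothing places it above or below the only other compound shown. Compound 3 `CN(C)Cc1ccncc1-c1ccc(-c2ccc3c(C(N)=O)nn(-c4ccc5onc(N)c5c4)c3c2F)c(F)c1` differs from compound 2 by 4-((dimethylamino)methyl)pyridin-3-yl in place of 5-((dimethylamino)methyl)-1H-pyrazol-4-yl on an aromatic carbon. No measured step bears on this change: the one step shown, a step that the two limits leave unreadable from compound 1 to compound 2, concerns a different group and is itself unreadable. The expectation for this assay therefore rests on compound 2 alone, and a step that the limit leaves unreadable from compound 2 to compound 3 is expected, meaning no resolved change. Compound 3 is estimated at 15000 nM, in the range 5000 nM to 50000 nM, and is most likely again reported only as a limit.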

Compound 3, inhibition constant: > 10000 nM
Compound 3 gave a limit, no number; the forecaster's own chance of this, stated with the estimate: 85%; the middle value lies beyond the limit too.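

Among these compounds, no step among compound 1, compound 2 and compound 3 can be read in this assay, as all three values are limits of the assay: the limit of > 10000 nM in this assay, at which 3 of the 3 values shown sit. The compounds shown leave open whether exchanging these groups on the shared core changes the result in this assay at all.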